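Methoxy on the Benzyl Ring: Expected Effect in Compound 4

The compounds below may be only part of what the source reports. "The series", "measured", "known", "first", "only" and "open" are said of these compounds alone.

Measured so far:
compound 1 `COc1cccc(OC)c1OCCNCCOc1ccccc1OCc1ccccc1` — 9.37
compound 2 `COc1cccc(OC)c1OCCNCCOc1ccccc1OCc1cccc(Cl)c1` — 8.72
compound 3 `COc1cccc(OC)c1OCCNCCOc1ccccc1OCc1ccc(C)cc1` — 9.12

Three compounds share one core and differ only in what sits on the benzyl ring. In a functional assay on thoracic aorta for antagonist activity at Alpha-1D adrenergic receptor (Rattus norvegicus) (a higher number here means a more potent compound, by a factor of ten per unit of this negative logarithm, a lower number a less potent compound), compound 1 gives 9.37, the highest of the three numbers. Its nearest neighbour is compound 3, and the step of a number 0.25 log units lower from compound 1 to compound 3 (within the scatter) stays within the scatter, so the two cannot be ranked. Its furthest neighbour is compound 2, and the step of a number 0.65 log units lower from compound 1 to compound 2 (beyond the scatter) lies beyond the scatter. Between the two substituted compounds the step of a number 0.40 log units higher from compound 2 to compound 3 (beyond the scatter) is also beyond the scatter.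

Compound 4 `COc1cccc(COc2ccccc2OCCNCCOc2c(OC)cccc2OC)c1` has not yet been measured. Relative to compound 1 the change is methoxy in place of hydrogen on an aromatic carbon.

Both measured steps from compound 1 bear on this: adding chloro gave a number 0.65 log units lower from compound 1 to compound 2 (beyond the scatter), adding methyl gave a number 0.25 log units lower from compound 1 to compound 3 (within the scatter). Each added group on the benzyl ring lowered the number, by a modest amount or by an amount within the scatter. A methoxy group is therefore expected to give a small step downward, estimated as a number 0.37 log units lower from compound 1 to compound 4 (beyond the scatter). Compound 4 is expected to reach about 9 in this assay, with a range from 8.5 to 9.4.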

Compound 4, negative logarithm of the antagonist equilibrium constant: 9.12
The estimate for compound 4 lay 0.12 log units below the measured number; the measured number falls inside the stated range.
By their numbers in this assay, from the lowest: compound 2; then compounds 3, 4 and 1 (each within the scatter of the next).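

In this assay placing methoxy on the benzyl ring gives a number 0.25 log units lower from compound 1 to compound 4 (within the scatter) and so cannot be told apart from leaving hydrogen there, which shows that this aromatic carbon can carry a group of two heavy atoms with no readable cost. Replacing chloro with methoxy on that same carbon gives a number 0.40 log units higher from compound 2 to compound 4 (beyond the scatter) and is the clearest new information. The drop seen with compound 2 is not shared by every added group at this place: it goes with chloro and not with methoxy. Comparing the two other substituted compounds gives no change at the digits printed from compound 3 to compound 4 (within the scatter) and leaves 3-methoxyphenyl and 4-methylphenyl indistinguishable, so compounds 1, 3 and 4 form one group within the scatter of each other, and compound 2 alone stands apart from them.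

From the compounds shown here alone, whether an amine, a carboxylic acid or a longer chain on this aromatic carbon would also stay level with compound 1 remains open. Nothing offered alongside these numbers gives a reason why chloro and methoxy part ways here.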